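A few compounds are considered here, and "the series" means these few. Any claim that something is new, unique, unknown or untested is made for them only; others in the source may bear on it.

Measured in a functional assay on PC-3 cells (Homo sapiens) for cytotoxicity, read by MTT assay, with a stated time of 48 h; on this read-out lower numbers stand for stronger inhibition and higher numbers for weaker inhibition:
Compound 1 `COc1cc(-n2c(-c3ccc(O)cc3)c[nH]c2=O)cc(OC)c1OC`: 30200 nM
Compound 2 `COc1ccc(-c2cn(C(=O)Nc3cc(OC)c(OC)c(OC)c3)c(=O)n2-c2cc(OC)c(OC)c(OC)c2)cc1OC`: > 50000 nM
Compound 3 `COc1cc(-n2c(-c3ccc(Br)cc3)cn(C(C)=O)c2=O)cc(OC)c1OC`: 3100 nM

Compound 2 stands at > 50000 nM, which is a limit of the assay and not a number. Of the two true numbers, compound 3 holds the lower at 3100 nM, and compound 1 gives 30200 nM. The gap between these two lies beyond the scatter. Compound 4 `COc1cc(-n2c(-c3ccc([N+](=O)[O-])cc3)cn(C(C)=O)c2=O)cc(OC)c1OC` has nitro in place of bromo on an aromatic carbon. Among the measured compounds shown here, no measured pair isolates a single change, so the expectation is loose. Expected in this assay is a modest move toward a higher number, a 1.6-fold higher number from compound 3 to compound 4 (0.21 log units; within the scatter). Compound 4 is estimated at 5000 nM, with an expected range of 1500 nM to 20000 nM.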

Compound 4, half-maximal inhibitory concentration: 32900 nM
For compound 4 the middle estimate is 6.6-fold (0.82 log units) below the measured one; measured number above the stated range.
By their numbers in this assay, from the lowest: compound 3; then compounds 1 and 4 (each within the scatter of the next). At a limit, above all of these: compound 2.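

Swapping 4-bromophenyl for 4-nitrophenyl gives the only single-place comparison in this assay, and it is a large one: an 11-fold higher number from compound 3 to compound 4 (1.03 log units; beyond the scatter). The read-out at this aromatic carbon therefore depends strongly on which group sits there, with the rest of the structure unchanged. Nothing shown accounts for the size of this step. The compounds shown leave open how an amine or a carboxylic acid at this place would read, and whether bromo is especially favoured or nitro especially poor.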